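Swapping an aryl group for an aroyl group on compound 2

The compounds below may be only part of what the source reports. "The series", "measured", "known", "first", "only" and "open" are said of these compounds alone.

Measured in a functional assay on MDA-MB-231 cells (Homo sapiens) for antiproliferative activity, read by MTT assay, with a stated time of 24 h; a higher number here means a weaker inhibitor, a lower number a stronger inhibitor:
- Compound 1 `O=C(NNc1cccc(Cl)c1)c1ccc(NS(=O)(=O)c2cnc(O)nc2O)cc1`: 17400 nM
- Compound 2 `O=C(NNc1ccccc1Cl)c1ccccc1NS(=O)(=O)c1cnc(O)nc1O`: 18900 nM
- Compound 3 `Cc1ccc(C(=O)NNC(=O)c2ccc(NS(=O)(=O)c3cnc(O)nc3O)cc2)cc1`: > 20000 nM, a limit of the assay and not a number

Compound 2 at 18900 nM and compound 1 at 17400 nM lie within the usual scatter of each other, so neither can be ranked above the other in this assay. Compound 3 gives no number to compare, only (the limit of > 20000 nM in this assay, at which 1 of the 3 values shown sits).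

The next compound, compound 4 `Cc1ccccc1C(=O)NNC(=O)c1ccccc1NS(=O)(=O)c1cnc(O)nc1O`, is made from compound 2 by one change: (2-methylphenyl)carbonyl in place of 2-chlorophenyl on an amine nitrogen, ((2-methylphenyl)carbonyl in place of 2-chlorophenyl on an amine nitrogen).

Going by the values given here, only one measured step is of the same kind, with (4-methylphenyl)carbonyl in place of 3-chlorophenyl on an amine nitrogen: an at least 1.1-fold higher number from compound 1 to compound 3 (0.06 log units; that floor lies within the scatter). That is a floor and not a true size, and it stays within the scatter. It therefore points weakly towards a higher number, meaning a weaker inhibitor, but it does not fix how large the step is. The expected change is small, a 1.2-fold higher number from compound 2 to compound 4 (0.07 log units; within the scatter). Compound 4 may well be expected to end at a limit too. For compound 4 the estimated value is 22000 nM, with an expected range from 12000 nM to 40000 nM.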

Compound 4, half-maximal inhibitory concentration: 5570 nM
Estimate against measurement, compound 4: 3.9-fold (0.60 log units) above; measured number outside the range, below it.
By their numbers in this assay, from the lowest: compound 4; then compounds 1 and 2 (each within the scatter of the next). At a limit, above all of these: compound 3.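

At this place, on an amine nitrogen whose other neighbour is an amide-type nitrogen, swapping 2-chlorophenyl for (2-methylphenyl)carbonyl gives a change in this assay that can be read with confidence: a 3.4-fold lower number from compound 2 to compound 4 (0.53 log units; beyond the scatter). The related step, an at least 1.1-fold higher number from compound 1 to compound 3 (0.06 log units; that floor lies within the scatter), had pointed weakly the other way, but the two pairs carry different groups, and the compounds shown therefore give this kind of swap no single direction. Compound 3 remains a limit of the assay and not a number, so the true size of that earlier step stays unknown, and only the newer step has a measured size: the limit of > 20000 nM in this assay, at which 1 of the 4 values shown sits.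

The step from compound 2 to compound 4 adds a carbonyl and exchanges chlorine for methyl at once, and the compounds shown do not separate these two changes. A (2-chlorophenyl)carbonyl group on this nitrogen would help to separate them, while an acetyl group or a longer alkyl chain there would test whether the aromatic ring of the entering group matters at all.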